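The source may report more compounds than this note shows. Statements on the series, on what has been measured and on what is new or still open speak of the compounds shown alone.

Measured so far in a functional assay on NCI-H1299 cells (Homo sapiens) for inhibition, read by CCK-8 assay, with a stated time of 72 h, tested at 10 uM; on this read-out higher numbers stand for more inhibition of growth at the one concentration tested and lower numbers for less inhibition of growth:
- compound 1 `CN(C)C(=O)c1cc2cnc(Nc3ccc(NC(=O)C4(C(=O)Nc5ccc(F)cc5)CC4)cc3)nc2n1C1CCCC1`: 90.8%
- compound 2 `CN(C)C(=O)c1cc2cnc(Nc3ccc(NC(=O)C4(C(=O)Nc5cccc(O)c5)CC4)cc3)nc2n1C1CCCC1`: 78.5%

Compound 2, at 78.5%, is the lower of these two. Compound 3 `CN(C)C(=O)c1cc2cnc(Nc3ccc(NC(=O)C4(C(=O)Nc5ccccc5F)CC4)cc3)nc2n1C1CCCC1` carries 2-fluorophenyl in place of 3-hydroxyphenyl on an amide-type nitrogen. Within the data shown here, only one measured step bears on this: a number 12.3 percentage points lower from compound 1 to compound 2 (beyond the scatter), which swapped 4-fluorophenyl for 3-hydroxyphenyl at that same place. Since 2-fluorophenyl is not the same group as 4-fluorophenyl, only part of that modest step is expected to return in this assay. The expected change is a number 7.5 percentage points higher from compound 2 to compound 3 (within the scatter). The estimated value for compound 3 is 86%, within an expected range of 74% to 96%.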

Compound 3, percent growth inhibition at one concentration: 89.6%
Compound 3: the middle estimate sits 3.6 percentage points below what was measured, within the range that was stated.
By their numbers in this assay, from the lowest: compound 2; then compounds 3 and 1 (each within the scatter of the next).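

Changing to 2-fluorophenyl from 3-hydroxyphenyl on the amide-type nitrogen gives a number 11.1 percentage points higher from compound 2 to compound 3 (beyond the scatter) in this assay and shows that the lower number of compound 2 does not come with every new group at this place. Using 2-fluorophenyl in place of 4-fluorophenyl gives a number 1.2 percentage points lower from compound 1 to compound 3 (within the scatter) and so leaves these two fluorophenyl groups indistinguishable in this read-out. No available evidence explains the difference between the hydroxy and fluoro compounds. The compounds shown leave open how a chlorophenyl, methoxyphenyl or aminophenyl group would read here. They also leave open whether the lower number is particular to 3-hydroxyphenyl.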